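From a Five-Membered Ring to an Open Chain

The source may report more compounds than this note shows. Statements on the series, on what has been measured and on what is new or still open speak of the compounds shown alone.

In a functional assay on KB cells (Homo sapiens) for inhibition, read by MTT assay, with a stated time of 24 h, tested at 100 ug/mL (a lower number here means less inhibition of growth, a higher number more inhibition of growth at the concentration tested), compound 1 (`O=C(CCCCC1CCSS1)Nc1cccc(C(F)(F)F)c1`) gives 80%. Compound 3 (`O=C(CCCCC1CCSS1)Nc1ccc(Cl)cn1`) gives 74.5%, which lies within the scatter of compound 1, so the two cannot be told apart. Compound 2 (`O=C(CCCCC1CCSS1)Nc1ccc([N+](=O)[O-])c(C(F)(F)F)c1`) gives 49.5%, and the step that puts a nitro in place of hydrogen on an aromatic carbon is a number 30.5 percentage points lower from compound 1 to compound 2 (beyond the scatter).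

Compound 4 (`O=C(CCCCC(S)CCS)Nc1cccc(C(F)(F)F)c1`) differs from compound 1 in one place: a group of 5 heavy atoms (3 carbon, 2 sulfur; no ring) in place of a group of 5 heavy atoms (3 carbon, 2 sulfur; one five-membered non-aromatic ring with 2 hetero atoms), on a saturated chain carbon, four bonds along the chain from a carbonyl carbon. The entering group is 1,3-disulfanylpropyl, and it has not yet been measured. Going by the values given here, the nitro step is the only measured step from compound 1, and it leaves the five-membered ring untouched. It therefore gives no direct guide to the size or direction of this change. Compound 2 with 49.5% does show that one change to compound 1 can move the number a long way, so a wide range is warranted. Among the compounds with values here, with no direct precedent, only a modest drop is expected, and the estimated step is a number 8 percentage points lower from compound 1 to compound 4 (within the scatter). For compound 4 the estimate is 72%, with an expected range from 45% to 92%.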

Compound 4, percent growth inhibition at one concentration: 30.5%
For compound 4 the middle estimate is 41.5 percentage points above the measured one; measured number below the stated range.
By their numbers in this assay, from the lowest: compound 4; then compound 2; then compounds 3 and 1 (each within the scatter of the next).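

In this assay, replacing the five-membered ring of compound 1 with the open 1,3-disulfanylpropyl group gives a number 49.5 percentage points lower from compound 1 to compound 4 (beyond the scatter). So far the only step measured from compound 1 had been the nitro change on the aromatic ring, a number 30.5 percentage points lower from compound 1 to compound 2 (beyond the scatter), and the new step shows that the number also responds strongly to a change on a saturated chain carbon, four bonds along the chain from a carbonyl carbon. The two groups have the same count of carbon and sulfur atoms and differ in the ring, which is lost, and in the hydrogen-bond donors, which are gained, but no measurement at hand explains why the number falls.

The compounds shown leave open whether the drop goes with the loss of the ring or with the appearance of the hydrogen-bond donors, a question that an open chain with a methyl group on each sulfur could help to separate. They also leave open whether the same opening of the ring would lower the number for compound 3, whose aromatic part is different.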